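A few compounds are considered here, and "the series" means these few. Any claim that something is new, unique, unknown or untested is made for them only; others in the source may bear on it.

Measured: compound 1 `O=C(O)CCCCCOc1cc(-c2ccccc2)cc(-c2ccccc2)n1` gives 30 nM; compound 2 `O=C(O)CCCCCOc1cc(-c2ccc(C(F)(F)F)cc2)cc(-c2ccccc2)n1` gives 150 nM; compound 3 `CC(C)(CCCCOc1cc(-c2ccc(N)cc2)cc(-c2ccccc2)n1)C(=O)O` gives 9.5 nM.

In an assay for binding affinity to leukotriene B4 receptor 1 (Homo sapiens) (on this read-out higher numbers stand for weaker inhibition and lower numbers for stronger inhibition), compound 1 stands second highest of the three numbers, with compound 3 below it and compound 2 above it. Among the compounds with values here, the only single-place step known is a 5.0-fold higher number from compound 1 to compound 2 (0.70 log units; beyond the scatter). Compound 4 `NC(=O)CCCCCOc1cc(-c2ccccc2)cc(-c2ccccc2)n1` differs from compound 1 by amino in place of hydroxy on a carbonyl carbon. Within the data shown here, no measured step bears on the carbonyl end of the chain: the known step sits on an aromatic carbon, and compounds 1 and 3 differ in two places, so their values say nothing about this change on their own. The step from compound 1 to compound 4 is therefore expected with wide uncertainty, as a 5.0-fold higher number from compound 1 to compound 4 (0.70 log units; beyond the scatter). For compound 4 the estimate is 150 nM, with a range of 25 nM to 900 nM.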

Compound 4, half-maximal inhibitory concentration: 150 nM
Compound 4: middle estimate and measured number agree at the digits printed, within the range that was stated.
By their numbers in this assay, from the lowest: compound 3; then compound 1; then compounds 2 and 4 (each within the scatter of the next).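

In this assay the carbonyl end of the chain now has a measured step of its own, with a 5.0-fold higher number from compound 1 to compound 4 (0.70 log units; beyond the scatter) when carbamoyl replaces carboxy. The number at this end therefore responds to the exchange of a single heavy atom, hydroxy for amino, by a modest step beyond the scatter. No measurement at hand accounts for this step.

Going by these compounds, a methyl ester or a tetrazole at the chain end remains open. So does whether a shorter or longer chain would change the size of this step.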